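The source may report more compounds than this note shows. Statements on the series, on what has been measured and on what is new or still open speak of the compounds shown alone.

Series notes. In a functional assay on A549 cells (Homo sapiens) for antiproliferative activity, read by MTT assay, with a stated time of 72 h (a lower number here means a stronger inhibitor, a higher number a weaker inhibitor), compound 1 `CN1CCN(C(=S)SCc2ccc3nc(N)nc(N)c3c2)CC1` gives 9200 nM, the highest of the three numbers in hand. Compound 2 `Nc1nc(N)c2cc(CSC(=S)N3CCN(C4CCCCC4)CC3)ccc2n1` gives 4710 nM and compound 3 `Cc1ccc(N2CCN(C(=S)SCc3ccc4nc(N)nc(N)c4c3)CC2)c(C)c1` gives 3000 nM; the step of a 2.0-fold lower number from compound 1 to compound 2 (0.29 log units; within the scatter), the step of a 3.1-fold lower number from compound 1 to compound 3 (0.49 log units; beyond the scatter), and the step of a 1.6-fold lower number from compound 2 to compound 3 (0.20 log units; within the scatter). Compound 4 `Nc1nc(N)c2cc(CSC(=S)N3CCN(c4ccc(F)cc4F)CC3)ccc2n1` differs from compound 1 by 2,4-difluorophenyl in place of methyl on an amine nitrogen in a ring. The step from compound 1 to compound 3, 2,4-dimethylphenyl entering at the same place, is the one that bears on this change and it brought a modest drop beyond the scatter, whereas the cyclohexyl step stayed within it. A drop of similar modest size is therefore expected in this assay, a 2.9-fold lower number from compound 1 to compound 4 (0.46 log units; beyond the scatter). For compound 4 the estimate is 3200 nM, expected to fall between 1500 nM and 7000 nM.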

Compound 4, half-maximal inhibitory concentration: 5120 nM
The estimate for compound 4 lay 1.6-fold (0.20 log units) below the measured number; the measured number falls inside the stated range.
By their numbers in this assay, from the lowest: compounds 3, 2, 4 and 1 (each within the scatter of the next, the first and the last beyond it).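

In this assay, 2,4-difluorophenyl on the amine nitrogen in the ring leaves the number within the scatter of methyl (a 1.8-fold lower number from compound 1 to compound 4 (0.25 log units; within the scatter)), unlike 2,4-dimethylphenyl at the same place (a 3.1-fold lower number from compound 1 to compound 3 (0.49 log units; beyond the scatter)). It also stays within the scatter of both larger groups (a 1.7-fold higher number from compound 3 to compound 4 (0.23 log units; within the scatter); a 1.1-fold higher number from compound 2 to compound 4 (0.04 log units; within the scatter)), so compound 2, compound 3 and compound 4 cannot be ordered at this position. No data here explain these results. Open, on these data alone, is whether a basic amine, a carboxylic acid or unsubstituted phenyl at this nitrogen would move the number beyond the scatter.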